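Swapping the ether-linked heterocycle: expected oral bioavailability

This account rests on a few compounds, and the source may have more. Where it says the series, first, only, none or still open, it means among the compounds named here.

Compound 1 `CC(C)(C)c1cc(NC(=O)Nc2cccc(Oc3ccnc4[nH]c(=O)cnc34)c2)n(-c2ccccc2)n1` gives 6% in an in vivo ADME assay on the whole organism (strain C57BL/cAnNCrl) for pharmacokinetics, with Mus musculus as the target, at a dose of 10 mg/kg by the oral route; a lower number here means that a smaller share of the oral dose reaches the circulation, a higher number that a larger share of the oral dose reaches the circulation.
Compound 2 `Cc1nc2c(Oc3ccc(NC(=O)Nc4cc(C(F)(F)F)ccc4F)c4ccccc34)ccnc2[nH]c1=O` gives 4% in this assay.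
Compound 3 `Cc1ccc(-n2nc(C(C)(C)C)cc2NC(=O)Nc2ccc(Oc3ccnc4[nH]c(S)nc34)cc2F)cc1` gives 13% in this assay.

The three numbers all lie within the scatter of one another; the number of compound 3 is nearer to that of compound 1 than to that of compound 2, and neither gap exceeds the scatter. Compound 4 `Cc1ccc(-n2nc(C(C)(C)C)cc2NC(=O)Nc2ccc(Oc3ccnc4[nH]c(=O)cnc34)cc2F)cc1` differs from compound 3 by a group of 11 heavy atoms (7 carbon, 3 nitrogen, 1 oxygen; one six-membered aromatic ring with 1 hetero atom, one six-membered aromatic ring with 2 hetero atoms) in place of a group of 10 heavy atoms (6 carbon, 3 nitrogen, 1 sulfur; one five-membered aromatic ring with 2 hetero atoms, one six-membered aromatic ring with 1 hetero atom), on an oxygen on an aromatic ring. Among the measured compounds shown here, the entering group is the one carried by compound 1 and compound 2. Compound 4 is estimated at 5% (range 1% to 15%), because compound 1 with the same entering group gives 6% and compound 2 gives 4%. The expected step of a number 8 percentage points lower from compound 3 to compound 4 (within the scatter) is a small decrease that stays within the scatter.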

Compound 4, oral bioavailability: 24%
The estimate for compound 4 lay 19 percentage points below the measured number, and the stated range ends below it.
By their numbers in this assay, from the lowest: compounds 2, 1 and 3 (each within the scatter of the next); then compound 4.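

With the rest of the molecule unchanged, putting the group with two six-membered aromatic rings in place of the group with a five-membered aromatic ring, on an oxygen on an aromatic ring, gives a number 11 percentage points higher from compound 3 to compound 4 (beyond the scatter) in this assay. This is the first pair shown that differs in one place, and it shows that the group at this place alone can move oral bioavailability beyond the scatter. Nothing available explains the step.

Going by these compounds, whether the step carries over to other cores remains open. So does the effect of an amine or a carboxylic acid on the entering group.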